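A few compounds are considered here, and "the series" means these few. Any claim that something is new, unique, unknown or untested is made for them only; others in the source may bear on it.

Measured compounds in an assay on cells for displacement of a labelled ligand from corticotropin-releasing factor receptor 1 (Homo sapiens), with a stated time of 100 min; on this read-out lower numbers stand for stronger inhibition and higher numbers for weaker inhibition:
compound 1, `C=CCN(CC=C)Cc1c(C(F)(F)F)nc2n(-c3c(C)cc(C)cc3C)c(Cl)cn12`, 13 nM
compound 2, `Cc1cc(C)c(-n2c(Cl)cn3c(CN(CCC(F)(F)F)Cc4ccc(F)cc4)c(C(F)(F)F)nc23)c(C)c1`, 34 nM
compound 3, `Cc1cc(C)c(-n2c(Cl)cn3c(CN(CCC(F)(F)F)Cc4ccc(Cl)cc4)c(C(F)(F)F)nc23)c(C)c1`, 12 nM

Among these three, compound 1 has the second highest number; its nearest neighbour is compound 3, whose number is within the scatter of it, while compound 2 sits beyond the scatter with a higher number. Among the compounds with values here, the only step between measured compounds is the exchange of chloro for fluoro, giving a 2.8-fold lower number from compound 2 to compound 3 (0.45 log units; beyond the scatter); this touches a different part of the molecule and says nothing directly about the change that leads to compound 4, `Cc1cc(C)c(-n2c(Cl)cn3c(CN4CCCC4c4ccccc4)c(C(F)(F)F)nc23)c(C)c1`.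

That change is 2-phenylpyrrolidin-1-yl in place of diallylamino on a saturated chain carbon bound to an aromatic carbon. Within the data shown here, no measured pair shows what replacing the open diallylamino with the ring-closed 2-phenylpyrrolidin-1-yl does here, so there is no basis for expecting a step beyond the scatter in either direction. Compound 4 is therefore estimated at 15 nM, with a range of 4 nM to 60 nM. This estimate corresponds to an expected step of a 1.2-fold higher number from compound 1 to compound 4 (0.06 log units; within the scatter), which lies within the usual scatter.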

Compound 4, inhibition constant: > 7000 nM
Compound 4: no number, only a limit (the forecaster's own chance of this, stated with the estimate: 5%); at least 460-fold (2.66 log units) between middle value and limit.
By their numbers in this assay, from the lowest: compounds 3 and 1 (each within the scatter of the next); then compound 2. At a limit, above all of these: compound 4.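

Compound 4 gives no number in this assay, only a limit: the limit of > 7000 nM in this assay, at which 1 of the 4 values shown sits.

Putting 2-phenylpyrrolidin-1-yl in place of diallylamino on this saturated chain carbon bound to an aromatic carbon gives an at least 530-fold higher number from compound 1 to compound 4 (2.73 log units; beyond the scatter), a large step and the first one in the series to go far beyond the scatter. The earlier compounds shown here showed only a modest effect from a chloro for fluoro exchange elsewhere on the molecule, whereas this result shows that the group at this place can decide whether the compound registers in this assay at all.

The change brings in a ring and a phenyl at once, and this single step cannot separate the two. On these data alone, whether a plain pyrrolidin-1-yl without the phenyl, or an open dipropylamino group, would stay close to compound 1 remains open.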